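The source may report more compounds than this note shows. Statements on the series, on what has been measured and on what is new or still open speak of the compounds shown alone.

Measured compounds:
compound 1, `COC1CN(C(=O)/C=C/c2ccncc2-c2ccc3ccccc3c2)C1`, 42.8 nM
compound 2, `O=C(O)CCc1ccncc1-c1ccc2ccccc2c1`, 50.5 nM

Both were tested in an assay on a protein complex for inhibition of CDK8/Cyclin C (Homo sapiens), with a stated time of 1 h; on this read-out higher numbers stand for weaker inhibition and lower numbers for stronger inhibition. Compound 2, at 50.5 nM, shows the higher of the two numbers, but compound 1 at 42.8 nM stands close to it, and the gap between them lies within the usual scatter, so neither can be called the stronger inhibitor on this evidence. Compound 3, `CNC(=O)/C=C/c1ccncc1-c1ccc2ccccc2c1`, has not yet been measured in this assay. It differs from compound 2 in one place: 2-(methylcarbamoyl)ethenyl in place of 2-carboxyethyl on an aromatic carbon. Compound 1 also carries an ethenyl chain ending in an amide, and its number in this assay is not distinguishable from that of compound 2, so a step no larger than the scatter, if anything toward a slightly lower number, is expected: a 1.4-fold lower number from compound 2 to compound 3 (0.16 log units; within the scatter). For compound 3 the estimate in this assay is 35 nM, with a likely range from 12 nM to 100 nM.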

Compound 3, half-maximal inhibitory concentration: 12.4 nM
Beside the measured number, compound 3's estimate is 2.8-fold (0.45 log units) above it; the range from low to high includes it.
By their numbers in this assay, from the lowest: compound 3; then compounds 1 and 2 (each within the scatter of the next).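

In this assay, 2-(methylcarbamoyl)ethenyl in place of 2-carboxyethyl on this aromatic carbon, ortho to a large group and opposite the ring nitrogen, gives a 4.1-fold lower number from compound 2 to compound 3 (0.61 log units; beyond the scatter), a separation that the two earlier compounds, within the scatter of each other, did not show. With the ethenyl amide chain kept, the group on the carbonyl carbon also matters: methylamino in place of 3-methoxyazetidin-1-yl gives a 3.5-fold lower number from compound 1 to compound 3 (0.54 log units; beyond the scatter). Nothing available explains either step.

Going by these compounds, it remains open whether the double bond or the amide accounts for the step from compound 2, a question that an ethenyl chain ending in a carboxylic acid or a saturated chain ending in the methyl amide would separate. Also open, on these data alone, is how an unsubstituted amino group or a dimethylamino group on the carbonyl carbon would compare with methylamino.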